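The compounds below may be only part of what the source reports. "The series", "measured", "known", "first", "only" and "open" are said of these compounds alone.

Compound 2 `O=C(/N=C(/NC(=O)c1ccno1)[Se]Cc1ccccc1)c1ccno1` and compound 3 `O=C(/N=C(/NC(=O)c1cccs1)[Se]Cc1ccccc1)c1cccs1` are built on two different cores, and the difference between the two cores is not broken down here. In a functional assay on K562 cells (Homo sapiens) for cytotoxicity, read by MTT assay, with a stated time of 72 h (on this read-out higher numbers stand for weaker inhibition of growth and lower numbers for stronger inhibition of growth), compound 2 gives 20000 nM. In this assay compound 3 gives 29500 nM, and the two values lie within the usual scatter of each other.

Compound 1 `CS/C(=N\C(=O)c1ccno1)NC(=O)c1ccno1` differs from compound 2 by one change: a group of 2 heavy atoms (1 carbon, 1 sulfur; no ring) in place of a group of 8 heavy atoms (7 carbon, 1 selenium; one six-membered aromatic ring of carbon only), on a carbon with a double bond to nitrogen. In this assay compound 1 gives > 100000 nM, which is a limit of the assay and not a number. The step of an at least 5.0-fold higher number from compound 2 to compound 1 (0.69 log units; beyond the scatter) is therefore itself only a bound because of the limit of > 100000 nM in this assay, at which 1 of the 3 values shown sits.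

Compound 4 `CS/C(=N\C(=O)c1cccs1)NC(=O)c1cccs1` carries the same change on the core of compound 3: a group of 2 heavy atoms (1 carbon, 1 sulfur; no ring) in place of a group of 8 heavy atoms (7 carbon, 1 selenium; one six-membered aromatic ring of carbon only), on a carbon with a double bond to nitrogen. Compound 4 is expected to show a step of a 5.1-fold higher number from compound 3 to compound 4 (0.71 log units; beyond the scatter) in this assay, an expectation that rests on the measured step of an at least 5.0-fold higher number from compound 2 to compound 1 (0.69 log units; beyond the scatter) and on the starting value of compound 3 in this assay, 29500 nM. For compound 4 the estimate is 150000 nM, with a range from 60000 nM to 400000 nM, and it is likely that this assay will again report only a limit.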

Compound 4, concentration for 50% growth inhibition: 72600 nM
For compound 4 the middle estimate is 2.1-fold (0.32 log units) above the measured one; the range from low to high includes it.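

In this assay, putting methylsulfanyl in place of the selenium-containing group with its six-membered aromatic ring, on a carbon with a double bond to nitrogen, gives a 2.5-fold higher number from compound 3 to compound 4 (0.39 log units; beyond the scatter), so on both cores shown the change moves the number the same way. Set side by side, the two steps read: the same change on two cores in this assay, an at least 5.0-fold higher number (0.69 log units; beyond the scatter) from compound 2 to compound 1 and a 2.5-fold higher number (0.39 log units; beyond the scatter) from compound 3 to compound 4; the limit leaves it open whether they differ. This shows a shared direction on these two cores only and does not show that the size of the step carries over, as the step on the first core is only a bound, resting on a limit of the assay: the limit of > 100000 nM in this assay, at which 1 of the 4 values shown sits.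

The compounds shown leave open how benzylsulfanyl would read at this place, which would separate the exchange of selenium for sulfur from the loss of the aromatic ring, and how an amine or a longer chain would read there. They also leave open whether the step holds on any core beyond these two.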